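Swapping Trifluoromethyl for Methylcarbamoyl: Compound 3 to Compound 4

The source may hold more compounds than are shown below. What is called first, only, known or untested is meant among the compounds shown, and "the series" means these compounds.

In an assay for inhibition of Indoleamine 2,3-dioxygenase 1 (Homo sapiens), with stated times of 10 min and 60 min, tested at 100 uM (a higher number here means a stronger effect of the compound at the concentration tested, a lower number a weaker effect), three compounds have been measured so far:

compound 1 `O=C1NC(=O)c2c(NCc3ccccc3[N+](=O)[O-])cccc21`: 4%
compound 2 `N#Cc1cc(NCc2ccccc2[N+](=O)[O-])c2cn[nH]c2c1`: 17%
compound 3 `FC(F)(F)c1cccc(CNc2cc(C(F)(F)F)cc3[nH]ncc23)c1`: 49%

Compound 3 gives the highest number of the three. Its nearest neighbour is compound 2, whose value lies beyond the scatter below it, and the furthest is compound 1, whose value lies still further below. Compound 3 is thus the strongest of the measured set on these numbers.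

The next compound, compound 4 `CNC(=O)c1cccc(CNc2cc(C(F)(F)F)cc3[nH]ncc23)c1`, differs from compound 3 in one place: methylcarbamoyl in place of trifluoromethyl on an aromatic carbon. Among the measured compounds shown here, no pair of measured compounds shows a change of this kind, so the measured set offers no step to lean on; only the value of compound 3 is known as a starting point.

The account therefore expects a step from compound 3 to compound 4 of moderate size in the downward direction, though a result within the scatter cannot be ruled out; the expected step is a number 19 percentage points lower from compound 3 to compound 4 (beyond the scatter). For compound 4 the estimate is 30%, within a range from 10% to 55%.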

Compound 4, a percentage reported as inhibition, at one concentration (the size of the read-out at that concentration, not a potency): 46%
The estimate for compound 4 lay 16 percentage points below the measured number; the range from low to high includes it.
By their numbers in this assay, from the lowest: compound 1; then compound 2; then compounds 4 and 3 (each within the scatter of the next).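

In this assay, among the compounds shown here, the change from trifluoromethyl to methylcarbamoyl on an aromatic carbon, meta to a large group, provides the only step that can be read at this position, a number 3 percentage points lower from compound 3 to compound 4 (within the scatter). At this one place, a group with a hydrogen-bond donor and a hydrogen-bond acceptor thus takes the place of one with neither, and the read-outs of the two compounds at the single tested concentration cannot be told apart. Nothing shown here gives a reason why the two groups read alike.

Going by these compounds, whether the same holds for other groups at this place, such as a carboxylic acid, an amine or a longer chain, remains open. Also open, on these data alone, is whether compound 3 and compound 4 would still read alike as potencies, since this read-out gives the effect at one concentration only.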